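The source may report more compounds than this note shows. Statements on the series, on what has been measured and on what is new or still open speak of the compounds shown alone.

Measured compounds:
Compound 1, `COC(=O)C1=C(C)NC(=O)NC1c1ccccc1`: "not active" (no number reported) in an assay for inhibition of beta-glucuronidase (Bos taurus), read by spectrophotometry, with a stated time of 30 min; a higher number here means a weaker inhibitor, a lower number a stronger inhibitor
Compound 2, `COC(=O)C1=C(C)NC(=O)NC1c1ccc(O)cc1`: 17200 nM in this assay
Compound 3, `COC(=O)C1=C(C)NC(=O)NC1c1ccc(Cl)cc1`: 34200 nM in this assay

Compound 3 stands at one end of the two numbers reported; its nearest neighbour is compound 2, and the step of a 2.0-fold higher number from compound 2 to compound 3 (0.30 log units; within the scatter) does not separate the two beyond the usual scatter. Compound 1 carries no number at all. Compound 4, `COC(=O)C1=C(C)NC(=O)NC1c1ccc(Br)cc1`, differs from compound 3 in one place: bromo in place of chloro on an aromatic carbon. Among the measured compounds shown here, no measured step exchanges one halogen for another, so the only guide is the step of a 2.0-fold higher number from compound 2 to compound 3 (0.30 log units; within the scatter), where a far greater change of group at the same position left the reading within the scatter. A smaller change from chloro to bromo is therefore expected to move the reading no further, and the estimated step of a 1.1-fold lower number from compound 3 to compound 4 (0.06 log units; within the scatter) is meant to lie within the scatter. For compound 4 the expected value in this assay is 30000 nM, with a range from 12000 nM to 75000 nM.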

Compound 4, half-maximal inhibitory concentration: 64100 nM
Compound 4: middle estimate off by 2.1-fold (0.33 log units), on the low side; the range from low to high includes it.
By their numbers in this assay, from the lowest: compounds 2, 3 and 4 (each within the scatter of the next, the first and the last beyond it).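

Among the compounds shown here, with compound 4, a change of group at this position moves the reading in this assay beyond the scatter for the first time: a 3.7-fold higher number from compound 2 to compound 4 (0.57 log units; beyond the scatter), though only modestly. The exchange of one halogen for the other gives a 1.9-fold higher number from compound 3 to compound 4 (0.27 log units; within the scatter), so chloro and bromo are not separated here, and chloro also remains within the scatter of hydroxy. Hydroxy and bromo are thus the only pair at this position that the numbers tell apart, with compound 4 the weaker inhibitor of the two. Nothing available gives a reason for this difference. The compounds shown leave open how an amine, a methoxy group or a carboxylic acid at this position would read, and whether iodo would stay within the scatter of bromo.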